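A few compounds are considered here, and "the series" means these few. Any claim that something is new, unique, unknown or untested is made for them only; others in the source may bear on it.

Measured compounds:

Compound 1, `ClCc1ccccc1Cn1cnc2c(Cl)nc(Cl)nc21`, with 2040 nM in a functional assay on SN12C cells (Homo sapiens) for cytotoxicity, read by sulforhodamine B assay, with a stated time of 48 h; a lower number here means a stronger inhibitor of growth, a higher number a weaker inhibitor of growth.
Compound 2, `ClCc1ccccc1Cn1cnc2c(Cl)ncnc21`, with 8710 nM in this assay.
Compound 3, `ClCc1ccc(Cn2cnc3nc(Cl)nc(Cl)c32)cc1`, with 3460 nM in this assay.

Compound 1 and compound 2 differ in one place only: hydrogen in place of chloro on an aromatic carbon. That single change gave a 4.3-fold higher number from compound 1 to compound 2 (0.63 log units; beyond the scatter), a step that lies beyond the usual scatter of this measurement. Compound 3 is built from the same atoms as compound 1, joined differently; the difference between the two cores is not broken down here. Its value stands nearest to that of compound 1, within the scatter, and furthest from that of compound 2, beyond the scatter.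

Compound 4, `ClCc1ccc(Cn2cnc3ncnc(Cl)c32)cc1`, has not yet been measured in this assay. It differs from compound 3 in one place: hydrogen in place of chloro on an aromatic carbon. Going by the values given here, this is the same change as the one from compound 1 to compound 2, and the surroundings of the place are described in the same words for both pairs. The expectation for compound 4 therefore rests on the step seen from compound 1 to compound 2, since that is the only measured instance of the change among these compounds. On that basis compound 4 is expected to show a 4.0-fold higher number from compound 3 to compound 4 (0.61 log units; beyond the scatter) in this assay. The estimate for compound 4 in this assay is 14000 nM, with a likely range from 6000 nM to 35000 nM.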

Compound 4, concentration for total growth inhibition: 14800 nM
Estimate against measurement, compound 4: 1.1-fold (0.02 log units) below, and the stated range covers the measured number.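

Replacing the chloro group with hydrogen on the aromatic carbon between two ring nitrogen atoms gave, in this assay, a 4.3-fold higher number from compound 3 to compound 4 (0.63 log units; beyond the scatter), and set beside the same change on the core of compound 1 the step is of matching size: the same change on two cores in this assay, a 4.3-fold higher number (0.63 log units; beyond the scatter) from compound 1 to compound 2 and a 4.3-fold higher number (0.63 log units; beyond the scatter) from compound 3 to compound 4, 1.0-fold (0.00 log units) apart, within the scatter of two such steps. Within these two pairs, then, the loss of this chloro group raised the number by a like amount on both cores, so the step measured on one core described the step on the other, and both steps lie beyond the scatter. Going by these compounds alone, this does not show that the change would carry over to any further core or to other cells, since it rests on only two pairs in a single assay, and the agreement of the two steps gives no reason for the effect of the chloro group.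

The compounds shown leave open how an amine, a methoxy group or a bromo group would compare with chloro and hydrogen on that same aromatic carbon. They also leave open what happens when the chloromethyl group, which all four compounds carry, gives way to a hydroxymethyl group or a longer chain.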